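Working notes: compound 2 to compound 4, one methyl fewer

The source may report more compounds than this note shows. Statements on the series, on what has been measured and on what is new or still open speak of the compounds shown alone.

Measured in an ADME assay on microsomes from liver (Rattus norvegicus) for metabolic stability; a higher number here means that the compound lasts longer, a lower number that the compound disappears faster:
- compound 1 `CCC(CC)(c1nnc[nH]1)c1ccc(-c2ccc3cccc(F)c3c2)[nH]c1=O`: 0.925 h
- compound 2 `Cc1nc(C(c2ccc(-c3ccc4cccc(F)c4c3)[nH]c2=O)C(C)C)[nH]c1C`: 0.0733 h
- compound 3 `CC(C)[C@@H](C[C@H]1CCNC1=O)c1ccc(-c2ccc3cccc(F)c3c2)[nH]c1=O`: 0.507 h

Compound 2 gives the lowest of the three numbers in this assay. Compound 3 stands nearest, its number higher by a gap beyond the scatter, and compound 1 stands furthest, higher by a gap also beyond the scatter.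

Compound 4 `Cc1c[nH]c(C(c2ccc(-c3ccc4cccc(F)c4c3)[nH]c2=O)C(C)C)n1` is not yet measured. Its difference from compound 2: hydrogen in place of methyl on an aromatic carbon. Among the measured compounds shown here, no measured pair shows this change, so nothing in the numbers fixes its size or direction. The step from compound 2 to compound 4 is expected to be small, upward if anything, and within the scatter, as a 1.5-fold higher number from compound 2 to compound 4 (0.18 log units; within the scatter). Compound 4 is accordingly estimated at 0.11 h, with a range from 0.04 h to 0.35 h.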

Compound 4, half-life: < 0.0667 h
Compound 4: no number, only a limit; the forecaster's own chance of this, stated with the estimate: 5%; at least 1.6-fold (0.21 log units) between middle value and limit.
By their numbers in this assay, from the lowest: compound 2; then compounds 3 and 1 (each within the scatter of the next). At a limit, below all of these: compound 4.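

In this assay, compound 4 gives < 0.0667 h, which is a limit of the assay and not a number. Hydrogen in place of methyl on this aromatic carbon gives an at least 1.0-fold lower number from compound 2 to compound 4 (0.04 log units; that floor lies within the scatter), so this change shows no rise in half-life, and removing this methyl does not lift the series out of the low end of the range. The real size of the step cannot be read: the limit of < 0.0667 h in this assay, at which 1 of the 4 values shown sits.

Going by these compounds, what a fluorine or a trifluoromethyl on this aromatic carbon would do stays open. So does the outcome of hydrogen in place of the remaining methyl.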